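This account rests on a few compounds, and the source may have more. Where it says the series, first, only, none or still open, it means among the compounds named here.

Measured so far in a functional assay on the whole organism for antagonist activity, with Mus musculus as the target; a higher number here means that more compound is needed for the effect, a lower number that less compound is needed:
Compound 1, `COC(=O)N(C)CC#CCn1cncc1C`, gives > 100 mg/kg, which is a limit of the measurement rather than a number.
Compound 2, `CCOC(=O)N(C)CC#CCN1CCCC1`, gives > 100 mg/kg, also a limit.
Compound 3, `CCOC(=O)N(C)CC#CCn1cncc1C`, gives 30 mg/kg.

Compound 1 and compound 3 differ by methyl in place of hydrogen on a saturated chain carbon bound to an oxygen next to a carbonyl group, and that change gives an at least 3.3-fold lower number from compound 1 to compound 3 (0.52 log units; beyond the scatter). Compound 2 differs from compound 1 in its core, and that difference is not broken down here. Compound 4, `CCOC(=O)N(C)C(C)C#CCN1CCCC1`, has not yet been tested in this assay; it differs from compound 2 by methyl in place of hydrogen on a saturated chain carbon bound to an amide-type nitrogen and a triple-bonded carbon. Among the compounds with values here, this is the same kind of change as the one from compound 1 to compound 3, but not the same: in the earlier pair the methyl goes onto a saturated chain carbon bound to an oxygen next to a carbonyl group, while here it goes onto a saturated chain carbon bound to an amide-type nitrogen and a triple-bonded carbon. The earlier step is therefore only a loose guide. For compound 4 the expected step is a number no higher from compound 2 to compound 4 (the limit leaves the size open), resting on the earlier step and on (the limit of > 100 mg/kg in this assay, at which 2 of the 3 values shown sit), where compound 2 itself sits. The estimate for compound 4 is 100 mg/kg, between 30 mg/kg and 300 mg/kg, with a real chance that only a limit is again reported.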

Compound 4, dose for half-maximal effect: > 100 mg/kg
Compound 4 was reported as a limit; the forecaster's own chance of this, stated with the estimate: 60%; the middle value sits exactly at the limit.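

In this assay compound 4 gives > 100 mg/kg, which is a limit and not a number. Compound 2 gives > 100 mg/kg, also a limit, so no step can be read between these two compounds. The compounds shown leave open whether this added methyl changes the dose needed at all, and most values offer no number: the limit of > 100 mg/kg in this assay, at which 3 of the 4 values shown sit.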